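A few compounds are considered here, and "the series" means these few. Any claim that something is new, unique, unknown or untested is made for them only; others in the source may bear on it.

Measured so far in a functional assay on L02 cells (Homo sapiens) for inhibition, read by Griess assay, with stated times of 1 h and 24 h; a higher number here means a weaker inhibitor, a lower number a stronger inhibitor:
Compound 1 `CNc1nc(/C=C/c2ccccc2)nc2ccsc12` gives only a limit, > 1000000 nM.
Compound 2 `CN1CCN(c2nc(/C=C/c3ccccc3)nc3ccsc23)CC1` gives 198000 nM.

Going by the values given here, compound 2 thus stands on the only full number in this assay; the other value is a limit and not a number. Compound 1 sits at the limit of > 1000000 nM in this assay, at which 1 of the 2 values shown sits. Among the compounds with values here, the single measured step, an at least 5.0-fold lower number from compound 1 to compound 2 (0.70 log units; beyond the scatter), is known only as a bound for that reason, and it swaps one nitrogen substituent for another at the same position.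

Compound 3 `Brc1cccc(Nc2nc(/C=C/c3ccccc3)nc3ccsc23)c1` differs from compound 2 by (3-bromophenyl)amino in place of 4-methylpiperazin-1-yl on an aromatic carbon. Within the data shown here, the measured step bears on this only loosely: it shows that a change at this position can move the number at least modestly, but no measured pair compares an arylamino group with a ring amine, and no pair carries a bromine anywhere. Direction cannot be read from the data, so the working expectation is a step of no clear size, a 1.0-fold higher number from compound 2 to compound 3 (0.00 log units; within the scatter), within the scatter but with a wide spread either way. Compound 3 is therefore estimated at 200000 nM in this assay, with a range from 30000 nM to 1500000 nM.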

Compound 3, half-maximal inhibitory concentration: > 1000000 nM
Compound 3: only a limit was reported; the forecaster's own chance of this, stated with the estimate: 25%; middle value at least 5.0-fold (0.69 log units) away from the limit.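

Replacing 4-methylpiperazin-1-yl with (3-bromophenyl)amino gives an at least 5.0-fold higher number from compound 2 to compound 3 (0.70 log units; beyond the scatter) in this assay, so this position now has a measured step in the direction of a higher number, which the earlier step did not show. Among the three groups shown at this position, only the ring amine of compound 2 gives a full number, while methylamino and (3-bromophenyl)amino, the two groups with a hydrogen on the attached nitrogen, both end in a limit and not a number. The step between compound 1 and compound 3 cannot be read, because both stand at the same limit and the true distance between them is hidden: the limit of > 1000000 nM in this assay, at which 2 of the 3 values shown sit.

The compounds shown do not separate the contributions of the bromine, the aromatic ring and the hydrogen on the attached nitrogen, and a plain phenylamino group or a dimethylamino group at this position would bear on that. They also leave open whether the full number of compound 2 depends on the piperazine ring itself, or whether a morpholine or a piperidine at this position would give a comparable result.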